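Tert-butyl for Ethyl on a Second Core

The compounds below may be only part of what the source reports. "The series", "measured", "known", "first", "only" and "open" are said of these compounds alone.

Four compounds, two cores, one ester change. Compound 1 `CCOC(=O)/C(C#N)=C/c1ccoc1` and compound 2 `CC(C)(C)OC(=O)/C(C#N)=C/c1ccoc1` stand on one core, compound 3 `CCOC(=O)/C(C#N)=C/c1cc2ccccc2[nH]1` and compound 4 `CC(C)(C)OC(=O)/C(C#N)=C/c1cc2ccccc2[nH]1` on another. In a functional assay on the whole organism (strain CD1) for inhibition, with Mus musculus as the target, with stated times of 15 min and 20 min, at a dose of 10 mg/kg by the subcutaneous route (a lower number here means less inhibition, a higher number more inhibition at the dose given (going by the name of the read-out)), compound 1 gives 55.9% and compound 2 gives 81.8%. For the measured compounds named here, the step between them, a number 25.9 percentage points higher from compound 1 to compound 2 (beyond the scatter), is the single change (tert-butyl in place of ethyl on an oxygen next to a carbonyl group). Compound 3 gives 88.4% in this assay; its gap to compound 2 lies within the scatter, so no order between these two is drawn, while its gap to compound 1 lies beyond it. How the core of compound 1 differs from the core of compound 3 is not broken down here.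

Compound 4 is still unmeasured and carries the same change on the second core: tert-butyl in place of ethyl on an oxygen next to a carbonyl group. The place is the same word for word as in the earlier pair, so this is the same change, seen once on each core. It rests on one measured step only.

The expectation for compound 4 is a smaller step than a number 25.9 percentage points higher from compound 1 to compound 2 (beyond the scatter), because compound 3 already gives 88.4%, a higher starting point than compound 1 had. The step of a number 4.6 percentage points higher from compound 3 to compound 4 (within the scatter) is therefore expected to be positive but modest. The estimated value for compound 4 in this assay is 93%, with a range from 82% to 100%.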

Compound 4, a percentage reported as inhibition, in the whole organism at one dose (the size of the read-out at that dose, not a potency): 51.3%
Estimate against measurement, compound 4: 41.7 percentage points above, outside the stated range (below it).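

In this assay, tert-butyl in place of ethyl on an oxygen next to a carbonyl group does not carry over from one core to the other: on the second core the result is a number 37.1 percentage points lower from compound 3 to compound 4 (beyond the scatter), opposite in direction to the step on the first core. The two steps differ in sign and size: the same change on two cores in this assay, a number 25.9 percentage points higher (beyond the scatter) from compound 1 to compound 2 and a number 37.1 percentage points lower (beyond the scatter) from compound 3 to compound 4, 63 percentage points apart, beyond the scatter of two such steps

With one pair on each core, this shows that the outcome of this change in the series depends on the core it stands on, so a step seen on one core gives no safe forecast for the other; it does not show which feature of either core decides the outcome, how the change would behave on a further core, or how potency shifts, as the read-out is a percentage at a single dose.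

The ester groups shown are only ethyl and tert-butyl, which leaves open whether an isopropyl ester or a longer chain such as n-butyl would follow the first core or the second on each core. Going by these compounds, the nitrile stays the same in all four compounds, and a carboxylic acid or a primary amide in place of the ester also remains open on both cores.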